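Methoxy in place of the saturated ring on the shared core

The compounds below may be only part of what the source reports. "The series", "measured", "known", "first", "only" and "open" are said of these compounds alone.

Measured compounds in a functional assay on MGC-803 cells (Homo sapiens) for antiproliferative activity, read by CCK-8 assay, with a stated time of 72 h; on this read-out lower numbers stand for stronger inhibition and higher numbers for weaker inhibition:
- compound 1 `CC(=O)N1CC=C(c2ccn3c(-c4ccc(NC(=O)c5ccc([N+](=O)[O-])o5)cc4)cnc3c2)CC1`: 940 nM
- compound 2 `CC1(O)CCN(c2ccn3c(-c4ccc(NC(=O)c5ccc([N+](=O)[O-])o5)cc4)cnc3c2)CC1`: 3100 nM
- compound 3 `O=C(Nc1ccc(-c2cnc3cc(N4CCCC4)ccn23)cc1)c1ccc([N+](=O)[O-])o1`: 1150 nM

Compound 1 gives the lowest of the three numbers. Compound 3 sits within the scatter of it, a 1.2-fold higher number from compound 1 to compound 3 (0.09 log units; within the scatter), so no order between these two can be claimed. Compound 2 lies beyond the scatter, a 3.3-fold higher number from compound 1 to compound 2 (0.52 log units; beyond the scatter), a modest loss, and the step of a 2.7-fold lower number from compound 2 to compound 3 (0.43 log units; beyond the scatter) is of the same modest size in the other direction.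

Compound 4 `COc1ccn2c(-c3ccc(NC(=O)c4ccc([N+](=O)[O-])o4)cc3)cnc2c1` is not yet measured. It differs from compound 1 in one place: a group of 2 heavy atoms (1 carbon, 1 oxygen; no ring) in place of a group of 9 heavy atoms (7 carbon, 1 nitrogen, 1 oxygen; one six-membered non-aromatic ring with 1 hetero atom), on an aromatic carbon. Among the measured compounds shown here, the only steps that bear on it are those at the same aromatic carbon. Replacing the six-membered non-aromatic ring with a five-membered non-aromatic ring changed nothing beyond the scatter, a 1.2-fold higher number from compound 1 to compound 3 (0.09 log units; within the scatter); a second six-membered non-aromatic ring cost a modest amount, a 3.3-fold higher number from compound 1 to compound 2 (0.52 log units; beyond the scatter). Methoxy is a further move toward a smaller group, for which no measured step exists, so a step of modest size at most is expected in this assay, a 1.6-fold higher number from compound 1 to compound 4 (0.20 log units; within the scatter), most likely toward a higher number. The value of compound 4 is estimated at 1500 nM, between 500 nM and 5000 nM.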

Compound 4, half-maximal inhibitory concentration: 860 nM
Estimate against measurement, compound 4: 1.7-fold (0.24 log units) above; the measured number falls inside the stated range.
By their numbers in this assay, from the lowest: compounds 4, 1 and 3 (each within the scatter of the next); then compound 2.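

In this assay, the aromatic carbon opposite the ring nitrogen needs no saturated ring among these compounds: a 1.1-fold lower number from compound 1 to compound 4 (0.04 log units; within the scatter) and a 1.3-fold lower number from compound 3 to compound 4 (0.13 log units; within the scatter) both leave methoxy level with the ring-bearing groups. Among the compounds shown here, the only new step beyond the scatter, a 3.6-fold lower number from compound 2 to compound 4 (0.56 log units; beyond the scatter), sets 4-hydroxy-4-methylpiperidin-1-yl apart from the other three groups, so group size alone does not order this set, since the smallest and the largest group read alike. No supporting measurement accounts for this pattern.

From the compounds shown here alone, whether a small amine such as dimethylamino, a carboxylic acid or a longer chain such as butoxy at this carbon would stay level with methoxy or follow compound 2 remains open. Unsubstituted piperidin-1-yl would be needed to show whether the ring itself or its hydroxy and methyl groups go with the higher number of compound 2.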